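A Methyl Removed: From Compound 2 to Compound 4

The source may report more compounds than this note shows. Statements on the series, on what has been measured and on what is new or still open speak of the compounds shown alone.

Measured so far, in a functional assay on NCI-H460 cells (Homo sapiens) for antiproliferative activity, read by CCK-8 assay, with a stated time of 72 h, tested at 8 uM; on this read-out lower numbers stand for a weaker effect and higher numbers for a stronger effect at the one concentration tested:
compound 1 `CC(C)n1cnc2c(Nc3ccccc3)nc(NCOCc3ccc(/C=C/C(=O)Nc4ccccc4N)cc3)nc21` gives 53.1%
compound 2 `Cc1ccc(Nc2nc(Cl)nc3c2ncn3Cc2ccc(C(=O)Nc3ccccc3N)cc2)cc1` gives 82.5%
compound 3 `CC1CCN(c2nc(Cl)nc3c2ncn3Cc2ccc(/C=C/C(=O)Nc3ccccc3N)cc2)CC1` gives 10.8%

Compound 2 stands highest of the three numbers in this assay. Compound 1 is its nearest neighbour and sits below it by more than the scatter; compound 3 lies furthest below, also beyond the scatter. Among the compounds with values here, no two of the measured compounds differ in only one place, so no single structural step has a measured size among them.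

Compound 4 `Nc1ccccc1NC(=O)c1ccc(Cn2cnc3c(Nc4ccccc4)nc(Cl)nc32)cc1` differs from compound 2 in one place: hydrogen in place of methyl on an aromatic carbon. Hydrogen in place of methyl on an aromatic carbon is a small change, and the measured compounds give no direct reading of what it does. With nothing to suggest a large shift, the expected step is a number 7.5 percentage points lower from compound 2 to compound 4 (within the scatter), small and most likely within the scatter, if anything slightly downward. Compound 4 is therefore expected at 75%, with a range from 55% to 90%.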

Compound 4, a percentage reported as inhibition, at one concentration (the size of the read-out at that concentration, not a potency): 77.8%
Compound 4: middle estimate off by 2.8 percentage points, on the low side; the measured number falls inside the stated range.
By their numbers in this assay, from the lowest: compound 3; then compound 1; then compounds 4 and 2 (each within the scatter of the next).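

Within the data shown here, exchanging 4-methylphenyl for phenyl gives the first step in this set that can be read at a single position: in this assay, the change runs a number 4.7 percentage points lower from compound 2 to compound 4 (within the scatter). The methyl on this aromatic carbon, para to a large group, can therefore be replaced by hydrogen without a difference that this read-out can separate from the usual scatter, at least in this one pair and at this one concentration. No further measurement bears on this result or shows what lies behind it.

Still open, from the compounds shown here alone, is what a larger or differently charged group at this place, such as methoxy, an amine or a carboxylic acid, would do to the read-out. Also open, going by these compounds, is whether the same exchange would give a similar step in compounds with a different side chain.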